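Compound 3 to compound 4: one more methoxy

A few compounds are considered here, and "the series" means these few. Any claim that something is new, unique, unknown or untested is made for them only; others in the source may bear on it.

In an ADME assay on cells (Lymphocyte, Homo sapiens) for cytotoxicity, read by MTT assay, with a stated time of 48 h (a higher number here means a weaker inhibitor, a lower number a stronger inhibitor), compound 1 `COC(=O)/C(=C\c1ccc(O)cc1)Sc1ccnc2cc(Cl)ccc12` gives 33700 nM with hydrogen on the aromatic oxygen. Compound 2 `COC(=O)/C(=C\c1ccc(OC(=O)c2ccccc2OC)cc1)Sc1ccnc2cc(Cl)ccc12` gives > 100000 nM as a limit of the assay, not a number. Compound 3 `COC(=O)/C(=C\c1ccc(OC(=O)c2ccc(OC)c(OC)c2)cc1)Sc1ccnc2cc(Cl)ccc12` stands at 51100 nM and is not separated from compound 1, the step being a 1.5-fold higher number from compound 1 to compound 3 (0.18 log units; within the scatter) as measured.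

Compound 4 `COC(=O)/C(=C\c1ccc(OC(=O)c2ccc(OC)c(OC)c2OC)cc1)Sc1ccnc2cc(Cl)ccc12` carries one change relative to compound 3: methoxy in place of hydrogen on an aromatic carbon, ortho to a large group, which turns 3,4-dimethoxyphenyl into 2,3,4-trimethoxyphenyl.

Within the data shown here, no measured step adds a methoxy to an aryl group already in place, so the evidence is indirect. The 2-methoxyphenyl of compound 2 reappears within the 2,3,4-trimethoxyphenyl of compound 4, and that group gave an at least 2.9-fold higher number from compound 1 to compound 2 (0.47 log units; beyond the scatter) on going from the hydrogen. Exchanging it for 3,4-dimethoxyphenyl gave an at least 1.9-fold lower number from compound 2 to compound 3 (0.29 log units; that floor lies within the scatter) in the other direction. A small move toward a higher number in this assay is therefore expected, probably not beyond the scatter, and a result reported only as a limit remains possible.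

The expected change is a 1.4-fold higher number from compound 3 to compound 4 (0.15 log units; within the scatter) for this one group. The estimate for compound 4 is 72000 nM (expected range 35000 nM to 130000 nM).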

Compound 4, half-maximal inhibitory concentration: 22400 nM
The estimate for compound 4 lay 3.2-fold (0.51 log units) above the measured number, outside the stated range (below it).
By their numbers in this assay, from the lowest: compounds 4, 1 and 3 (each within the scatter of the next, the first and the last beyond it). At a limit, above all of these: compound 2.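

Among these compounds, compound 4 is the first case here of a methoxy added to an aryl group that already carries methoxy groups; at this place, ortho to a large group and ortho to a methoxy group, the change gives a 2.3-fold lower number from compound 3 to compound 4 (0.36 log units; beyond the scatter) in this assay. A methoxy ortho to the large group therefore does not by itself go with a higher number: 2-methoxyphenyl and 2,3,4-trimethoxyphenyl both carry one, yet exchanging the first for the second on the carbonyl carbon gives an at least 4.4-fold lower number from compound 2 to compound 4 (0.64 log units; beyond the scatter). The size of that second step is only a floor, as it starts from a limit and not from a number: the limit of > 100000 nM in this assay, at which 1 of the 4 values shown sits.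

Still open, from the compounds shown here alone, is whether the lower number belongs to methoxy itself or would also appear with an ethoxy, a fluorine or an amine at the same place on the 3,4-dimethoxyphenyl group. Also open, going by these compounds, is how far the result depends on the two methoxy groups already present, a question that a 2,3-dimethoxyphenyl or 2,4-dimethoxyphenyl group on the same carbonyl would address.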